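The source may hold more compounds than are shown below. What is called first, only, known or untested is meant among the compounds shown, and "the series" means these compounds.

In a functional assay on EKVX cells (Homo sapiens) for antiproliferative activity, read by sulforhodamine B assay, with a stated time of 48 h (a higher number here means a weaker inhibitor, a lower number a stronger inhibitor), compound 1 `C/C=C(\C)C(=O)O[C@H]1C=CC(=O)O[C@H]1CCC(=O)[C@H](C)O` gives 26000 nM and compound 2 `C/C=C(\C)C(=O)O[C@H]1C=CC(=O)O[C@H]1COC(=O)[C@H](C)O` gives 19000 nM, so the two lie within the scatter of each other. Compound 3 `C/C=C(\C)C(=O)O[C@H]1C=CC(=O)O[C@H]1CNC(=O)[C@H](C)O` carries ((1-hydroxyethyl)carbonyl)amino in place of ((1-hydroxyethyl)carbonyl)oxy on a saturated chain carbon bound to a saturated ring carbon. Going by the values given here, the only measured step at this place is a 1.4-fold lower number from compound 1 to compound 2 (0.14 log units; within the scatter). On that single step, no change beyond the scatter is expected in this assay. The expected step is a 1.2-fold higher number from compound 2 to compound 3 (0.06 log units; within the scatter). For compound 3 the estimated value is 22000 nM, with an expected range of 10000 nM to 50000 nM.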

Compound 3, half-maximal inhibitory concentration: 27000 nM
Compound 3: middle estimate off by 1.2-fold (0.09 log units), on the low side; low and high end bracket the measured number.
By their numbers in this assay, from the lowest: compounds 2, 1 and 3 (each within the scatter of the next).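

In this assay, ((1-hydroxyethyl)carbonyl)amino in place of ((1-hydroxyethyl)carbonyl)oxy gives a 1.4-fold higher number from compound 2 to compound 3 (0.15 log units; within the scatter), and in place of ((1-hydroxyethyl)carbonyl)methyl it gives a 1.0-fold higher number from compound 1 to compound 3 (0.02 log units; within the scatter), on a saturated chain carbon bound to a saturated ring carbon. Going by these compounds alone, with carbon, oxygen and now nitrogen as the linking atom, no step at this place lies beyond the scatter. No supporting measurement offers an explanation for this result. As far as these compounds go, whether a longer chain at this place, or an amine or a carboxylic acid in place of the (1-hydroxyethyl)carbonyl end, moves the number beyond the scatter stays open.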